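Swapping propyl for 1-phenylethyl in compound 2

A few compounds are considered here, and "the series" means these few. Any claim that something is new, unique, unknown or untested is made for them only; others in the source may bear on it.

Measured in a functional assay on K562 cells (Homo sapiens) for inhibition; a higher number here means a weaker inhibitor, a lower number a stronger inhibitor:
Compound 1 `CC(=O)OC1C(C(O)CO)OC2OC(C)(C)OC21`: 3800000 nM
Compound 2 `CCCCC(=O)OC1C(C(O)CO)OC2OC(C)(C)OC21`: 2000000 nM

On these numbers, compound 2 stands level with compound 1. Compound 3 `CC(CC(=O)OC1C(C(O)CO)OC2OC(C)(C)OC21)c1ccccc1` carries 1-phenylethyl in place of propyl on a saturated chain carbon bound to a carbonyl carbon. Among the measured compounds shown here, only one measured step bears on this change. It put propyl in place of hydrogen on that same kind of carbon and gave a 1.9-fold lower number from compound 1 to compound 2 (0.28 log units; within the scatter). For the measured compounds named here, no measured compound has an aromatic ring, so the expectation in this assay is no step beyond the scatter. The expected change is a 1.3-fold lower number from compound 2 to compound 3 (0.12 log units; within the scatter). For compound 3 the estimated value is 1500000 nM, with an expected range of 550000 nM to 3800000 nM.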

Compound 3, half-maximal inhibitory concentration: 500000 nM
Estimate against measurement, compound 3: 3.0-fold (0.48 log units) above; the whole stated range lies above it.
By their numbers in this assay, from the lowest: compound 3; then compounds 2 and 1 (each within the scatter of the next).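

In this assay the saturated chain carbon bound to a carbonyl carbon now proves able to move the number beyond the scatter. 1-Phenylethyl in place of propyl gives a clear step (a 4.0-fold lower number from compound 2 to compound 3 (0.60 log units; beyond the scatter)), and 1-phenylethyl in place of hydrogen gives a larger one (a 7.6-fold lower number from compound 1 to compound 3 (0.88 log units; beyond the scatter)). Propyl had given no such step, so compound 3, with its six-membered aromatic ring, is the first to stand apart. Nothing available explains this shift. On these data alone, whether a plain phenyl, a longer chain or an amine here would do the same stays open.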